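A few compounds are considered here, and "the series" means these few. Any claim that something is new, unique, unknown or untested is made for them only; others in the source may bear on it.

The measured compounds are these. Compound 1 has the structure `CS/C(=N\C(=O)c1ccc(Cl)cc1)NC(=O)c1ccc(Cl)cc1`; in a functional assay on PC-3 cells (Homo sapiens) for cytotoxicity, read by MTT assay (on this read-out lower numbers stand for stronger inhibition and higher numbers for weaker inhibition), compound 1 gives > 10000 nM, which is a limit of the assay rather than a number. Compound 2 has the structure `C[Se]/C(=N\C(=O)c1ccc(Cl)cc1)NC(=O)c1ccc(Cl)cc1`, and in this assay compound 2 gives 7600 nM. Compound 3 has the structure `CS/C(=N\C(=O)c1ccc(C)cc1)NC(=O)c1ccc(C)cc1`; in this assay compound 3 gives > 10000 nM, again a limit and not a number.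

Between compound 1 and compound 2 the change is a group of 2 heavy atoms (1 carbon, 1 selenium; no ring) in place of a group of 2 heavy atoms (1 carbon, 1 sulfur; no ring), on a carbon with a double bond to nitrogen. The step that it made is an at least 1.3-fold lower number from compound 1 to compound 2 (0.11 log units; that floor lies within the scatter), and because the limit of > 10000 nM in this assay, at which 2 of the 3 values shown sit, the size of this step cannot be fixed more closely. How the core of compound 1 differs from the core of compound 3 is not broken down here.

Compound 4, with the structure `C[Se]/C(=N\C(=O)c1ccc(C)cc1)NC(=O)c1ccc(C)cc1`, is not yet measured in this assay. It differs from compound 3 by a group of 2 heavy atoms (1 carbon, 1 selenium; no ring) in place of a group of 2 heavy atoms (1 carbon, 1 sulfur; no ring), on a carbon with a double bond to nitrogen, the same change as from compound 1 to compound 2, at a place described in the same words. Compound 3 sits at the limit of the assay, so the expected step of an at least 1.1-fold lower number from compound 3 to compound 4 (0.04 log units; that floor lies within the scatter) rests on the earlier step of an at least 1.3-fold lower number from compound 1 to compound 2 (0.11 log units; that floor lies within the scatter) alone, and it is estimated to be small, as that earlier one was. Compound 4 is therefore expected to give 9000 nM in this assay, estimated to lie between 4000 nM and 20000 nM, with a fair chance that only a limit is reported.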

Compound 4, half-maximal inhibitory concentration: 1850 nM
Compound 4: middle estimate off by 4.9-fold (0.69 log units), on the high side, outside the stated range (below it).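

On the core of compound 3, putting the group of carbon and selenium in place of methylsulfanyl, on a carbon with a double bond to nitrogen, gives an at least 5.4-fold lower number from compound 3 to compound 4 (0.73 log units; beyond the scatter) in this assay, so on both cores shown the selenium compound gives the lower number, and on this core the step is beyond the scatter. The two steps, set side by side, read as follows: the same change on two cores in this assay, an at least 1.3-fold lower number (0.11 log units; that floor lies within the scatter) from compound 1 to compound 2 and an at least 5.4-fold lower number (0.73 log units; beyond the scatter) from compound 3 to compound 4; the limit leaves it open whether they differ What this does not show is that the change is worth the same on each core, or more on one than on the other, since neither step has a fixed size and each gives only a floor: the limit of > 10000 nM in this assay, at which 2 of the 4 values shown sit.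

The compounds shown leave open whether the change carries to cores that hold a methoxy or a nitro group where these cores hold chlorine or methyl. They also leave open how a longer chain on the selenium or the sulfur, such as ethyl or benzyl, or an amine on that same carbon, would read in this assay.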